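Aryl swap on a limit-bound member of the series

This account rests on a few compounds, and the source may have more. Where it says the series, first, only, none or still open, it means among the compounds named here.

Working notes on the series. In a functional assay on DU-145 cells (Homo sapiens) for inhibition, read by trypan blue exclusion, with a stated time of 96 h (a lower number here means a stronger inhibitor of growth, a higher number a weaker inhibitor of growth), compound 1 `COc1cc(/C=C(\C(=O)c2ccc(Cl)cc2)S(=O)(=O)Cc2ccccc2Cl)cc(OC)c1` gives only a limit, > 100000 nM, so it sits at the edge of what can be read rather than at a number. Compound 2 `Cc1ccc(S(=O)(=O)/C(=C/c2c(F)c(F)c(F)c(F)c2F)C(=O)c2ccc(Cl)cc2)cc1` likewise returns a limit in this assay, > 100000 nM. Compound 3 `O=C(O)c1ccc(C(=O)/C(=C\c2ccc(Br)c([N+](=O)[O-])c2)SCc2ccc(Cl)cc2Cl)cc1` stands apart, giving 1000 nM in this assay. Two of the three values shown therefore sit at the limit of > 100000 nM in this assay, at which 2 of the 3 values shown sit, and compound 1 is one of them; nothing more precise is known of where it stands.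

Compound 4 `CCOc1ccc(/C=C(\C(=O)c2ccc(Cl)cc2)S(=O)(=O)Cc2ccccc2Cl)cc1OC` is not yet measured. It differs from compound 1 in one place: 4-ethoxy-3-methoxyphenyl in place of 3,5-dimethoxyphenyl on a double-bonded chain carbon bound to a double-bonded chain carbon. The rest of compound 1 stays as it is. Among the measured compounds shown here, with compound 1 resting at a limit and no measured step of this kind at hand, the expected size of the step is none beyond the scatter, most likely ending again at a limit; the estimated step in this assay is a number no higher from compound 1 to compound 4 (the limit leaves the size open). Compound 4 is thus expected at 100000 nM, with a range from 30000 nM to 300000 nM.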

Compound 4, concentration for 50% growth inhibition: 10000 nM
Beside the measured number, compound 4's estimate is 10-fold (1.00 log units) above it; the measured number lies below the stated range.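

Position note: the aryl group on a double-bonded chain carbon bound to a double-bonded chain carbon is the first place in the series shown where a single change moves a compound off the limit. In this assay, 4-ethoxy-3-methoxyphenyl in place of 3,5-dimethoxyphenyl gives an at least 10-fold lower number from compound 1 to compound 4 (1.00 log units; beyond the scatter). This step gives only a minimum for the size of the change, with one end resting on a limit shared by two compounds: the limit of > 100000 nM in this assay, at which 2 of the 4 values shown sit.

The step changes the alkoxy groups and their ring positions together, so it leaves open whether the ethoxy group or the altered substitution pattern accounts for the shift. Also open, as far as these compounds go, is how this position would respond to a longer chain such as propoxy, or to an amine or a carboxylic acid on the aryl ring.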